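A few compounds are considered here, and "the series" means these few. Any claim that something is new, unique, unknown or untested is made for them only; others in the source may bear on it.

The measured compounds:
Compound 1 `Cc1nc(-c2ccc(OCC(C)C)c(C#N)c2)sc1C(=O)NCc1ccc(F)cc1` gives 2.86 in a physicochemical assay for lipophilicity; on this read-out higher numbers stand for higher lipophilicity and lower numbers for lower lipophilicity.
Compound 2 `Cc1nc(-c2ccc(OCC(C)C)c(C#N)c2)sc1C(=O)OCC(C)C` gives 0 in this assay.
Compound 3 `COC(=O)c1sc(-c2ccc(OCC(C)C)c(C#N)c2)nc1C` gives 1.63 in this assay.

Compound 1 stands highest of the three in this assay. Compound 3 is nearest to it, a number 1.23 log units lower from compound 1 to compound 3 (beyond the scatter), and compound 2 is furthest, a number 2.86 log units lower from compound 1 to compound 2 (beyond the scatter). Between the two esters the numbers run upward, a number 1.63 log units higher from compound 2 to compound 3 (beyond the scatter).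

The unmeasured compound 4 `Cc1nc(-c2ccc(OCC(C)C)c(C#N)c2)sc1C(=O)n1ccc(N)nc1=O` differs from compound 1 at a single place: a group of 8 heavy atoms (4 carbon, 3 nitrogen, 1 oxygen; one six-membered aromatic ring with 2 hetero atoms) in place of a group of 9 heavy atoms (7 carbon, 1 nitrogen, 1 fluorine; one six-membered aromatic ring of carbon only), on a carbonyl carbon. For the measured compounds named here, no measured step puts a ring of this kind on the carbonyl carbon, so the analogy is loose. The two steps that bear on the change are those in which the same (4-fluorobenzyl)amino group leaves compound 1, a number 2.86 log units lower from compound 1 to compound 2 (beyond the scatter) and a number 1.23 log units lower from compound 1 to compound 3 (beyond the scatter); both were large and both pointed downward, although the groups that entered there were simple alkoxy groups rather than an aromatic ring bearing hetero atoms.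

On that basis compound 4 is expected to sit well below compound 1, an estimated step of a number 2.06 log units lower from compound 1 to compound 4 (beyond the scatter). Compound 4 is therefore estimated at 0.8 in this assay, with a range from -0.2 to 1.8.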

Compound 4, partition coefficient: 1.59
Estimate against measurement, compound 4: 0.79 log units below; measured number inside the range.
By their numbers in this assay, from the lowest: compound 2; then compounds 4 and 3 (each within the scatter of the next); then compound 1.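

In this assay, an aromatic ring with hetero atoms now sits on the carbonyl carbon, and the move away from (4-fluorobenzyl)amino still costs a large step (a number 1.27 log units lower from compound 1 to compound 4 (beyond the scatter)), so keeping an aromatic ring in the group does not hold the number at the level of compound 1. The new group, with 8 heavy atoms, matches the methoxy group with 2 (a number 0.04 log units lower from compound 3 to compound 4 (within the scatter)), while it stands well apart from the isobutoxy group with 5 (a number 1.59 log units higher from compound 2 to compound 4 (beyond the scatter)). Across these four compounds, the number therefore does not follow the heavy-atom count of the group on the carbonyl carbon, and compound 2 is the one that breaks any such order.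

The compounds shown leave open how a plain benzylamino group, a morpholine amide or a free carboxylic acid on the same carbonyl carbon would compare, and so which part of the (4-fluorobenzyl)amino group goes with the high number of compound 1. No measurement offered here explains any of these steps.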